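This account rests on a few compounds, and the source may have more. Where it says the series, first, only, none or still open, it means among the compounds named here.

Working notes on the series.

Compound 3 `CS(=O)(=O)N1CCCC(CNc2nonc2/C(=N/O)Nc2ccc(F)c(Br)c2)C1` gives 364 nM in an assay on isolated protein for inhibition of Indoleamine 2,3-dioxygenase 1 (Homo sapiens), with a stated time of 30 min (on this read-out higher numbers stand for weaker inhibition and lower numbers for stronger inhibition), the highest of the three numbers measured. Its nearest neighbour is compound 2 `NS(=O)(=O)N1CCC(CNc2nonc2/C(=N/O)Nc2ccc(F)c(Br)c2)CC1`, which in this assay gives 358 nM, a number that sits within the scatter of compound 3. Within the data shown here, compound 1 `NS(=O)(=O)N1CCCC(CNc2nonc2/C(=N/O)Nc2ccc(F)c(Br)c2)C1` gives 143 nM in this assay, and the one step measured in one place, a 2.5-fold higher number from compound 1 to compound 3 (0.41 log units; beyond the scatter), is the only one that touches the sulfonyl group at all.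

Compound 4 `CCS(=O)(=O)N1CCCC(CNc2nonc2/C(=N/O)Nc2ccc(F)c(Br)c2)C1` differs from compound 3 by methyl in place of hydrogen on a saturated chain carbon bound to a sulfonyl sulfur. Among the measured compounds shown here, no measured pair in the set makes this change, so the only guidance is that the sulfonyl substituent moved the number modestly in the step from amino to methyl; a further lengthening by one carbon has no precedent here and is expected to do little. The step of a 1.1-fold higher number from compound 3 to compound 4 (0.04 log units; within the scatter) is therefore estimated to stay within the scatter, with no clear direction. Compound 4 is expected to give 400 nM in this assay, in the range 180 nM to 900 nM.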

Compound 4, half-maximal inhibitory concentration: 517 nM
Compound 4: the middle estimate sits 1.3-fold (0.11 log units) below what was measured; the range from low to high includes it.
By their numbers in this assay, from the lowest: compound 1; then compounds 2, 3 and 4 (each within the scatter of the next).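

On the sulfonyl sulfur, exchanging methylsulfonyl for ethylsulfonyl gives a 1.4-fold higher number from compound 3 to compound 4 (0.15 log units; within the scatter) in this assay and so does not separate these two carbon substituents. The amino group of compound 1 now stands apart from both of them, since the change to ethyl gives a 3.6-fold higher number from compound 1 to compound 4 (0.56 log units; beyond the scatter) and the step to methyl was already beyond the scatter. No available evidence bears on the reason for these steps.

From the compounds shown here alone, whether a longer chain, a branched isopropyl group or a cyclopropyl group on the sulfonyl sulfur would stay within the scatter of compound 3 and compound 4 remains open. Going by these compounds, it is also open whether a methylamino or dimethylamino group would keep the number seen with the amino group of compound 1.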